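Swapping the Nitrophenyl Arm for Pyridine in a Cytotoxicity Series

The compounds below may be only part of what the source reports. "The series", "measured", "known", "first", "only" and "open" are said of these compounds alone.

Within the data shown here, the three measured members share one core and differ only in the group on a single aromatic carbon. In an ADME assay on HepG2 cells (Homo sapiens) for cytotoxicity, read by MTT assay, with a stated time of 72 h (on this read-out lower numbers stand for higher toxicity in this test and higher numbers for lower toxicity in this test), compound 1 `CC1(c2ccc(-c3ccccc3C#N)cc2)CC(S(=O)(=O)c2ccc(F)cc2)=C(c2ccc(/C(N)=N\O)cc2)O1` gives 58300 nM. In this assay compound 2 `CC1(c2ccc(Cl)cc2)CC(S(=O)(=O)c2ccc(F)cc2)=C(c2ccc(/C(N)=N\O)cc2)O1` gives 61400 nM, and the step of a 1.1-fold higher number from compound 1 to compound 2 (0.02 log units; within the scatter) stays within the scatter. For compound 3 `CC1(c2ccc(-c3cccc([N+](=O)[O-])c3)cc2)CC(S(=O)(=O)c2ccc(F)cc2)=C(c2ccc(/C(N)=N\O)cc2)O1` the read-out is a limit, > 50000 nM. Because of the limit of > 50000 nM in this assay, at which 1 of the 3 values shown sits, the steps a step that the limit leaves unreadable from compound 1 to compound 3 and a step that the limit leaves unreadable from compound 2 to compound 3 cannot be sized, so compound 3 cannot be ranked against the other two on the numbers shown.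

Compound 4 `CC1(c2ccc(-c3ccncc3)cc2)CC(S(=O)(=O)c2ccc(F)cc2)=C(c2ccc(/C(N)=N\O)cc2)O1` differs from compound 3 by pyridin-4-yl in place of 3-nitrophenyl on an aromatic carbon. Among the measured compounds shown here, the only readable step in the set, a 1.1-fold higher number from compound 1 to compound 2 (0.02 log units; within the scatter), lies within the scatter, and the two steps ending in compound 3 are unreadable; no measured step tracks the exchange of one aromatic ring for another carrying a hetero atom. The expectation is therefore no movement beyond the scatter, with a fair chance that this assay again reports only a limit. Compound 4 is estimated at 55000 nM, with a range from 25000 nM to 120000 nM, which means the expected step that the limit leaves unreadable from compound 3 to compound 4.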

Compound 4, half-maximal cytotoxic concentration: 30300 nM
For compound 4 the middle estimate is 1.8-fold (0.26 log units) above the measured one; the range from low to high includes it.
By their numbers in this assay, from the lowest: compounds 4, 1 and 2 (each within the scatter of the next, the first and the last beyond it).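

Among these compounds, at this aromatic carbon, para to a large group, pyridin-4-yl gives the first step beyond the scatter in this assay, against chloro: a 2.0-fold lower number from compound 2 to compound 4 (0.31 log units; beyond the scatter). Among the compounds shown here, that step is modest, and against 2-cyanophenyl the same group gives a 1.9-fold lower number from compound 1 to compound 4 (0.28 log units; within the scatter), so the pyridine separates from only one of the two groups that can be compared with it by measured numbers, while compound 1 and compound 2 remain within the scatter of each other. Against 3-nitrophenyl the exchange gives an at least 1.6-fold lower number from compound 3 to compound 4 (0.21 log units; that floor lies within the scatter), and only this floor can be read, with the full size of the step out of reach because of a single read-out: the limit of > 50000 nM in this assay, at which 1 of the 4 values shown sits.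

The compounds shown do not tell whether the ring nitrogen of pyridin-4-yl is what sets compound 4 apart from compound 2, as no other aromatic ring with a hetero atom stands at this carbon for comparison. They also leave open whether an amine or a carboxylic acid at the same place would stay within the scatter of these values in this assay or move beyond it.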